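Swapping the fused ring of a urea series for a pyridine-type ring

A few compounds are considered here, and "the series" means these few. Any claim that something is new, unique, unknown or untested is made for them only; others in the source may bear on it.

Compound 1 `O=C(Nc1ccc(-n2ncc3c(C(F)(F)F)cccc32)cc1)Nc1ccc(Cl)c(C(F)(F)F)c1`: 2000 nM
Compound 2 `O=C(Nc1ccc(-n2ncc3c(F)cccc32)cc1)Nc1ccc(Cl)c(C(F)(F)F)c1`: 3100 nM
Compound 3 `CNc1cccc2c1cnn2-c1ccc(NC(=O)Nc2ccc(Cl)c(C(F)(F)F)c2)cc1`: 3600 nM

All three share a urea core and were tested in a functional assay on MDA-MB-231 cells (Homo sapiens) for cytotoxicity, read by MTT assay, with a stated time of 72 h; on this read-out higher numbers stand for weaker inhibition and lower numbers for stronger inhibition. Compound 2 sits in the middle of the three numbers, and its gaps to the others, a 1.6-fold higher number from compound 1 to compound 2 (0.19 log units; within the scatter) and a 1.2-fold higher number from compound 2 to compound 3 (0.06 log units; within the scatter), both fall within the scatter. The third step, a 1.8-fold higher number from compound 1 to compound 3 (0.26 log units; within the scatter), is within the scatter as well. Each of these steps swaps one small group on the same aromatic carbon of the fused ring, and none of them moved the number beyond what repeated measurement alone would give.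

Compound 4 `O=C(Nc1ccc(-n2ncc3ccncc32)cc1)Nc1ccc(Cl)c(C(F)(F)F)c1` goes one step further: a group of 9 heavy atoms (6 carbon, 3 nitrogen; one five-membered aromatic ring with 2 hetero atoms, one six-membered aromatic ring with 1 hetero atom) in place of a group of 10 heavy atoms (7 carbon, 2 nitrogen, 1 fluorine; one five-membered aromatic ring with 2 hetero atoms, one six-membered aromatic ring of carbon only), on an aromatic carbon. Going by the values given here, the whole fused ring is exchanged, not just a substituent, so no measured step covers this change directly. What the data do show is that the fused ring tolerates three different groups at this position without a clear effect. On that basis no step beyond the scatter is expected in this assay, in either direction. The estimated step of a 1.0-fold lower number from compound 2 to compound 4 (0.01 log units; within the scatter) is expected to stay within the scatter. For compound 4 the expected value in this assay is 3000 nM, with a range from 1200 nM to 7500 nM.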

Compound 4, half-maximal inhibitory concentration: > 32000 nM
Compound 4: only a limit was reported; the forecaster's own chance of this, stated with the estimate: 5%; middle value at least 10-fold (1.02 log units) away from the limit.
By their numbers in this assay, from the lowest: compounds 1, 2 and 3 (each within the scatter of the next). At a limit, above all of these: compound 4.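

Up to this point, swaps of a small group on the fused ring among compound 1, compound 2 and compound 3 had stayed within the scatter in this assay, but those swaps left the six-membered ring itself unchanged. Exchanging the 4-fluoro-1H-indazol-1-yl group for a group with a nitrogen in its six-membered ring and no fluorine gives an at least 10-fold higher number from compound 2 to compound 4 (1.01 log units; beyond the scatter), so this position is far less forgiving of a change to the ring than of a change to the small group on it. The figure for compound 4 is only a limit, which means the full size of this step cannot be read: the limit of > 32000 nM in this assay, at which 1 of the 4 values shown sits.

Compound 4 gains the ring nitrogen and loses the fluoro group in one step, so the compounds shown leave open which of the two changes accounts for the result, or whether both are needed. On these data alone, it also remains open whether a fluoro, trifluoromethyl or methylamino group on the ring of compound 4 would bring the number back into the range of the first three compounds, and how a methoxy group or a carboxylic acid would fare on either ring.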